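A few compounds are considered here, and "the series" means these few. Any claim that something is new, unique, unknown or untested is made for them only; others in the source may bear on it.

Measured compounds, all read in a functional assay on HCT-116 cells (Homo sapiens) for antiproliferative activity, read by MTT assay, with a stated time of 72 h; a higher number here means a weaker inhibitor, a lower number a stronger inhibitor:
compound 1 `CN(C(=O)CCc1ccccc1)c1ccc2[nH]c(-c3n[nH]c4ccccc34)cc2n1` gives 11200 nM
compound 2 `COc1cccc(C(=O)N(C)c2ccc3[nH]c(-c4n[nH]c5ccccc45)cc3n2)c1` gives 14200 nM
compound 3 `Cc1ccc(S(=O)(=O)N(C)c2ccc3[nH]c(-c4n[nH]c5ccccc45)cc3n2)cc1` gives 13300 nM

Compound 3 stands second highest of the three numbers; its nearest neighbour is compound 2 and the furthest is compound 1, and both gaps lie within the scatter, so no order can be read among these three. The steps that exchange the group on the methylated nitrogen are all small: a 1.3-fold higher number from compound 1 to compound 2 (0.10 log units; within the scatter), a 1.2-fold higher number from compound 1 to compound 3 (0.07 log units; within the scatter) and a 1.1-fold lower number from compound 2 to compound 3 (0.03 log units; within the scatter). Whether an acyl or a sulfonyl group with a phenyl, methoxyphenyl or methylphenyl sits there, the number stays in one band.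

Compound 4 `COc1ccc(S(=O)(=O)N(C)c2ccc3[nH]c(-c4n[nH]c5ccccc45)cc3n2)c(OC)c1` differs from compound 3 by 2,4-dimethoxyphenyl in place of 4-methylphenyl on a sulfonyl sulfur. The shared core, the methylated nitrogen and the sulfonyl stay untouched; the change is of the same kind as the three measured steps, each of which stayed within the scatter. No step beyond the scatter is therefore expected in this assay from compound 3 to compound 4. The estimated step is a 1.0-fold lower number from compound 3 to compound 4 (0.01 log units; within the scatter), none beyond the scatter. Compound 4 is expected at 13000 nM, with a range from 5500 nM to 32000 nM.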

Compound 4, half-maximal inhibitory concentration: 21800 nM
For compound 4 the middle estimate is 1.7-fold (0.22 log units) below the measured one; the range from low to high includes it.
By their numbers in this assay, from the lowest: compounds 1, 3, 2 and 4 (each within the scatter of the next).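

On the sulfonyl sulfur, 2,4-dimethoxyphenyl (10 heavy atoms, 2 hydrogen-bond acceptors) in place of 4-methylphenyl (7 heavy atoms, 0 hydrogen-bond acceptors) gives, in this assay, a 1.6-fold higher number from compound 3 to compound 4 (0.21 log units; within the scatter) and this is the first step shown that keeps the sulfonyl and exchanges only the aryl group on it. The earlier steps shown here exchanged the group on a carbonyl carbon or replaced an acyl group with a sulfonyl group, so they said nothing about the group on this sulfur taken alone. Here a larger aryl group carrying hydrogen-bond acceptors leaves the number within the scatter, and no data shown here explain the size of this step.

On these data alone, it remains open whether a group of another kind on the sulfonyl sulfur, such as a longer chain ending in an amine or a phenyl carrying a carboxylic acid, would give a step beyond the scatter. As far as these compounds go, all four compounds also keep the methyl on the nitrogen and the shared core, so the effect of an ethyl group or a hydrogen on that nitrogen, or of any change to the core, stays open.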